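A Single Substituent Exchange on a Shared Core

The source may report more compounds than this note shows. Statements on the series, on what has been measured and on what is new or still open speak of the compounds shown alone.

Three compounds share one core. In a functional assay on U-266 cells (Homo sapiens) for inhibition, read by MTT assay, with a stated time of 48 h, tested at 0.1 uM (a lower number here means less inhibition, a higher number more inhibition at the concentration tested (going by the name of the read-out)), compound 1 `Cc1noc(C)c1-c1ccc2c(c1)C(c1ccccc1)NC(=O)N2C` gives 13.1%. Compound 2 `Cc1noc(C)c1-c1ccc2c(c1)C(c1ccccc1)N(Cc1nc(-c3ccccc3)cs1)C(=O)N2C` gives 12.7% in this assay, and compound 3 `Cc1nc(-c2ccc(F)cc2)sc1CN1C(=O)N(C)c2ccc(-c3c(C)noc3C)cc2C1c1ccccc1` gives 10%. Compound 2 stands second highest of the three numbers, within the scatter of compound 1 and of compound 3. Going by the values given here, the one step between compounds differing in a single place runs a number 0.4 percentage points lower from compound 1 to compound 2 (within the scatter): placing (4-phenyl-1,3-thiazol-2-yl)methyl in place of hydrogen on an amide-type nitrogen in a ring altered nothing beyond the scatter.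

Compound 4 `Cc1noc(C)c1-c1ccc2c(c1)C(c1ccccc1)N(Cc1nnc(-c3ccc(F)cc3)o1)C(=O)N2C` differs from compound 2 as follows: 5-(4-fluorophenyl)-1,3,4-oxadiazol-2-yl in place of 4-phenyl-1,3-thiazol-2-yl on a saturated chain carbon bound to an amide-type nitrogen in a ring. Among the compounds with values here, no measured step exchanges one such group for another on that carbon. The nearest guides are the step from compound 1 to compound 2, which stayed within the scatter, and compound 3, whose related group also leaves it within the scatter of compound 2. No step beyond the scatter is therefore expected in this assay. Compound 4 is expected to give 12%, between 4% and 21%. For compound 4 this means an expected step of a number 0.7 percentage points lower from compound 2 to compound 4 (within the scatter), within the scatter.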

Compound 4, a percentage reported as inhibition, at one concentration (the size of the read-out at that concentration, not a potency): 26.8%
Compound 4: middle estimate off by 14.8 percentage points, on the low side; the measured number lies above the stated range.
By their numbers in this assay, from the lowest: compounds 3, 2 and 1 (each within the scatter of the next); then compound 4.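

Placed on the saturated chain carbon bound to the amide-type nitrogen in a ring, 5-(4-fluorophenyl)-1,3,4-oxadiazol-2-yl in place of 4-phenyl-1,3-thiazol-2-yl gives, in this assay, a number 14.1 percentage points higher from compound 2 to compound 4 (beyond the scatter), so the group at this position can move the read-out, which the earlier step from hydrogen to the thiazolylmethyl group did not show. The exchange alters the five-membered aromatic ring and adds fluorine in one move, so the step cannot be assigned to either change alone. Nothing measured here accounts for the step.

On these data alone, it remains open whether 5-phenyl-1,3,4-oxadiazol-2-yl, without the fluorine, would keep this higher number, and how an amine or a carboxylic acid on the phenyl ring would read. Also open, as far as these compounds go, is how the step would look across other concentrations, since a single concentration gives no potency.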